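Removing the piperazine methyl from compound 2

This account rests on a few compounds, and the source may have more. Where it says the series, first, only, none or still open, it means among the compounds named here.

- Compound 1 `Cc1cn2cc(-c3cc4ccc(N5CCN(C)CC5)cc4c(=O)o3)nc2cn1`: < 10 ng.h/mL (a limit of the assay)
- Compound 2 `Cc1cn2cc(-c3cc4ccc(N5CCN(C)CC5)cc4c(=O)o3)nc2c(C)n1`: 790 ng.h/mL

Among the compounds with values here, in an ADME assay on the whole organism (Rattus norvegicus, strain Sprague-Dawley) for pharmacokinetics, with a stated time of 6 h, at a dose of 10 mg/kg by the oral route (on this read-out higher numbers stand for higher exposure at the dose given and lower numbers for lower exposure), compound 2 gives 790 ng.h/mL, the only actual number so far. Compound 1 gives < 10 ng.h/mL, which is a limit and not a number. Within the data shown here, the single measured step, an at least 79-fold higher number from compound 1 to compound 2 (1.89 log units; beyond the scatter), is large, but it concerns a methyl on an aromatic carbon. Compound 3 `Cc1cn2cc(-c3cc4ccc(N5CCNCC5)cc4c(=O)o3)nc2c(C)n1` changes somewhere else: hydrogen in place of methyl on an amine nitrogen in a ring, or 4-methylpiperazin-1-yl to piperazin-1-yl. That measured step shows that one methyl can matter greatly in this assay, yet it gives no direct guide to this different change. A modest fall is therefore expected, with real uncertainty about its direction, and the estimated change is a 2.0-fold lower number from compound 2 to compound 3 (0.30 log units; within the scatter). For compound 3 the estimate is 400 ng.h/mL, with an expected range from 100 ng.h/mL to 1300 ng.h/mL.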

Compound 3, area under the concentration-time curve: 280 ng.h/mL
Compound 3: middle estimate off by 1.4-fold (0.15 log units), on the high side, and the stated range covers the measured number.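

The methyl on the piperazine nitrogen also affects exposure, though less dramatically than the aromatic methyl seen earlier: the change to piperazin-1-yl gives a 2.8-fold lower number from compound 2 to compound 3 (0.45 log units; beyond the scatter). This modest step lies beyond the usual scatter, so this ring nitrogen is a second place in the series where one small change can shift oral exposure, and compound 3, with hydrogen on that nitrogen, still gives a real number, 280 ng.h/mL, in this assay. Only compound 1 rests on a limit and not on a number: the limit of < 10 ng.h/mL in this assay, at which 1 of the 3 values shown sits.

The compounds shown leave open how a larger group on this nitrogen, such as an ethyl or an acetyl, would behave. A single exposure figure also cannot reveal what lies behind the fall from compound 2 to compound 3.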